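Halogen swap on the aryl ring of a pyrazole hydroxamate

A few compounds are considered here, and "the series" means these few. Any claim that something is new, unique, unknown or untested is made for them only; others in the source may bear on it.

Compound 1 `O=C(NOCc1ccccc1)c1cn(-c2ccccc2)nc1-c1ccc(Cl)cc1` gives 10800 nM in a functional assay on MCF7 cells (Homo sapiens) for antiproliferative activity, read by MTT assay, with a stated time of 48 h, in the presence of a further agent that is not named here; on this read-out higher numbers stand for weaker inhibition of growth and lower numbers for stronger inhibition of growth.
Compound 2 `O=C(NOCc1ccccc1F)c1cn(-c2ccccc2)nc1-c1ccc(Cl)cc1` gives 15100 nM in this assay.
Compound 3 `O=C(NOCc1ccc(Cl)cc1Cl)c1cn(-c2ccccc2)nc1-c1ccc(Cl)cc1` gives 16200 nM in this assay.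

Compound 3 stands at the highest of the three numbers, yet its steps to both others lie within the scatter: a 1.5-fold higher number from compound 1 to compound 3 (0.18 log units; within the scatter) and a 1.1-fold higher number from compound 2 to compound 3 (0.03 log units; within the scatter). Compound 4 `O=C(NOCc1ccc(Cl)cc1Cl)c1cn(-c2ccccc2)nc1-c1ccc(F)cc1` differs from compound 3 by fluoro in place of chloro on an aromatic carbon. For the measured compounds named here, no measured step touches this ring; the only halogen change measured, a 1.4-fold higher number from compound 1 to compound 2 (0.15 log units; within the scatter), sits elsewhere and was within the scatter, as were all three steps. The account therefore expects no step beyond the scatter, with a 1.0-fold lower number from compound 3 to compound 4 (0.01 log units; within the scatter) as the expected change. Compound 4 is estimated at 16000 nM, with a range from 8000 nM to 35000 nM.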

Compound 4, concentration for 50% growth inhibition: 25300 nM
For compound 4 the middle estimate is 1.6-fold (0.20 log units) below the measured one; the range from low to high includes it.
By their numbers in this assay, from the lowest: compounds 1, 2, 3 and 4 (each within the scatter of the next, the first and the last beyond it).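

For the compounds shown here, the first measured change on this ring, 4-chlorophenyl to 4-fluorophenyl, gives in this assay a result that reads a 1.6-fold higher number from compound 3 to compound 4 (0.19 log units; within the scatter), so this swap of one halogen for another, para to a large group, stays inside the usual variation, like the earlier steps elsewhere on the molecule. Nothing available here offers an explanation for this step. The compounds shown leave open how an amine or a carboxylic acid would read at this position, and whether the same halogen swap would give a similar step with the unsubstituted benzyl-side phenyl of compound 1.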